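A few compounds are considered here, and "the series" means these few. Any claim that something is new, unique, unknown or untested is made for them only; others in the source may bear on it.

Measured compounds:
Compound 1, `NS(=O)(=O)c1ccc(-c2nc3cc([N+](=O)[O-])ccc3[nH]2)cc1`, in a functional assay for antagonist activity at Neuropeptides B/W receptor type 1 (Homo sapiens), read by cAMP accumulation (on this read-out higher numbers stand for weaker inhibition and lower numbers for stronger inhibition), gives > 31600 nM, a limit of the assay.
Compound 2, `O=[N+]([O-])c1ccc2[nH]c(-c3ccc(C(F)(F)F)cc3)nc2c1`, in this assay gives > 31600 nM, also a limit of the assay.

Compound 2 thus stands at the limit of this assay, and no number is known for it. The same holds for compound 1. The step that the two limits leave unreadable from compound 1 to compound 2 cannot be read because of the limit of > 31600 nM in this assay, at which 2 of the 2 values shown sit. Compound 3, `O=[N+]([O-])c1ccc2[nH]c(-c3ccc(N4CCCC4)cc3)nc2c1`, differs from compound 2 by pyrrolidin-1-yl in place of trifluoromethyl on an aromatic carbon. No measured step bears on this change: the only step shown, from a sulfamoyl to a trifluoromethyl group, is unreadable. The expectation for this assay therefore rests on nothing but two limits, and a shift beyond the scatter cannot be predicted in either direction. Compound 3 is expected to give about 30000 nM, within 3000 nM to 100000 nM, which would mean an expected step of an at least 1.0-fold lower number from compound 2 to compound 3 (0.02 log units; that floor lies within the scatter).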

Compound 3, half-maximal inhibitory concentration: 1810 nM
Compound 3: middle estimate off by 17-fold (1.22 log units), on the high side; measured number below the stated range.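

In this assay, pyrrolidin-1-yl in place of trifluoromethyl on an aromatic carbon gives an at least 17-fold lower number from compound 2 to compound 3 (1.24 log units; beyond the scatter), and pyrrolidin-1-yl in place of sulfamoyl gives an at least 17-fold lower number from compound 1 to compound 3 (1.24 log units; beyond the scatter). Both sizes are only floors, because the starting compounds sit at a limit of the assay: the limit of > 31600 nM in this assay, at which 2 of the 3 values shown sit. The group at this place, para to a large group, can therefore move the read-out well beyond the scatter, something the earlier pair could not show, as its step cannot be read.

From the compounds shown here alone, what a piperidine ring or an open-chain diethylamino group would give at the same place remains open. Whether the step belongs to the ring of pyrrolidin-1-yl or to its nitrogen therefore cannot yet be told from the compounds shown.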